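The compounds below may be only part of what the source reports. "The series", "measured", "known", "first", "only" and "open" are said of these compounds alone.

Of the compounds shown here, two built on a shared core have been measured in an assay on mitochondria from L6 cells (Rattus norvegicus) for activation, with a stated time of 90 min; a lower number here means that less compound is needed, a higher number that more compound is needed for the effect. Compound 1 `Fc1ccc(C(F)(F)F)cc1Nc1nc2nonc2nc1Nc1cc(C(F)(F)F)ccc1F` gives only a limit in this assay, < 1000 nM. Among the compounds with values here, compound 2 `Fc1cccc(Nc2nc3nonc3nc2Nc2ccccc2F)c1` gives 190 nM in this assay, and that is the only number among the values shown. The remaining value is a limit rather than a number (the limit of < 1000 nM in this assay, at which 1 of the 2 values shown sits), so compound 2 cannot be ranked against compound 1. Within the data shown here, no step between two measured compounds that differ in one place is available, and the effect of exchanging one aryl group for another has not been seen.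

Compound 3 `Cc1ccc(Nc2nc3nonc3nc2Nc2ccccc2F)cc1` differs from compound 2 in one place: 4-methylphenyl in place of 3-fluorophenyl on a nitrogen on an aromatic ring. Among the measured compounds shown here, with no measured step to point either way, the step from compound 2 to compound 3 is expected to stay within the usual scatter of this assay, with no clear direction. Compound 3 is therefore estimated at 250 nM, with a range from 80 nM to 800 nM, and the step this estimate implies is a 1.3-fold higher number from compound 2 to compound 3 (0.12 log units; within the scatter).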

Compound 3, half-maximal effective concentration: 2100 nM
Compound 3: middle estimate off by 8.4-fold (0.92 log units), on the low side, and the stated range ends below it.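

Within the data shown here, the exchange of 3-fluorophenyl for 4-methylphenyl gives the first measured step, and in this assay it is large: an 11-fold higher number from compound 2 to compound 3 (1.04 log units; beyond the scatter). This shows that the aryl group on this nitrogen matters to the read-out, even though the rest of the molecule stays the same and the two groups match in heavy-atom count, in having one six-membered aromatic ring of carbon only, and in their zero counts of hydrogen-bond donors and acceptors. Compound 1 offers no further measured comparison here, as it carries a different pattern of groups and what stands for it is a limit and not a number: the limit of < 1000 nM in this assay, at which 1 of the 3 values shown sits.

Among these compounds, the single step changes both the substituent and its place on the ring, so it remains open whether the higher number goes with the methyl group or with the 4-position, a question that 3-methylphenyl or 4-fluorophenyl at this position could help to separate. From the compounds shown here alone, it is also open how this position would respond to a ring bearing a methoxy group, an amine or a carboxylic acid.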